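The source may hold more compounds than are shown below. What is called first, only, known or untested is meant among the compounds shown, and "the series" means these compounds.

In a functional assay on the whole organism for agonist activity, with Mus musculus as the target (on this read-out lower numbers stand for an effect already at smaller amounts and higher numbers for an effect only at larger amounts of compound), compound 1 (`COC(=O)N(C)CC#CCN(C)C`) gives 17.3 mg/kg and compound 2 (`COC(=O)N(C)C(C)C#CCN1CCCC1`) gives 9.7 mg/kg in the same test. These two numbers lie within the usual scatter of each other, so compound 2 does not stand apart from compound 1 on the data so far. Compound 3 (`COC(=O)N(C)C(C)C#CCN(C)C`) has not yet been measured. It carries dimethylamino in place of pyrrolidin-1-yl on a saturated chain carbon bound to a triple-bonded carbon. Among the compounds with values here, no measured pair shows this exchange on its own, so the expectation in this assay rests on little, and no step beyond the scatter is anticipated. The expected change is small, with the estimate pointing to a 1.3-fold higher number from compound 2 to compound 3 (0.13 log units; within the scatter) and staying within the scatter. For compound 3 the estimated value is 13 mg/kg with an expected range from 6 mg/kg to 30 mg/kg in this test.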

Compound 3, dose for half-maximal effect: 11.8 mg/kg
Compound 3: the middle estimate sits 1.1-fold (0.04 log units) above what was measured; the measured number falls inside the stated range.
By their numbers in this assay, from the lowest: compounds 2, 3 and 1 (each within the scatter of the next).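

Compound 3 lets the two changes be read separately in this assay: dimethylamino in place of pyrrolidin-1-yl on a saturated chain carbon bound to a triple-bonded carbon gives a 1.2-fold higher number from compound 2 to compound 3 (0.09 log units; within the scatter) and stays within the scatter. Methyl in place of hydrogen on a saturated chain carbon bound to an amide-type nitrogen and a triple-bonded carbon gives a 1.5-fold lower number from compound 1 to compound 3 (0.17 log units; within the scatter) and also stays within the scatter. On this read-out neither exchange sets a compound apart, and no measurement is at hand that would explain the numbers. Still open, going by these compounds, is whether ethyl in place of that methyl, or piperidin-1-yl in place of pyrrolidin-1-yl, would give a step beyond the scatter. On these data alone, whether any group at these two places can do so also remains open.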